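Benzyl on the Ring Nitrogen of a Long-Chain Core

The source may report more compounds than this note shows. Statements on the series, on what has been measured and on what is new or still open speak of the compounds shown alone.

Measured so far:
compound 1, `CCCCCCCCCCCCCCCCCC/N=c1\nc(N)c2nc[nH]c2c(N)n1`, in a functional assay on A549 cells (Homo sapiens) for antiproliferative activity, read by WST assay, with a stated time of 72 h (a lower number here means a stronger inhibitor, a higher number a weaker inhibitor), gives 1850 nM.
compound 2, `Nc1n/c(=N\CCCCc2ccccc2)nc(N)c2c1ncn2Cc1ccccc1`, in this assay gives 15300 nM.

Compound 1 holds the lowest of the two numbers in this assay; compound 2 sits well beyond the scatter on the weaker side, but the two differ in more than one place, so their gap cannot be pinned to a single change.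

Compound 3, `CCCCCCCCCCCCCCCCCC/N=c1\nc(N)c2ncn(Cc3ccccc3)c2c(N)n1`, is built from compound 1 by one change: benzyl in place of hydrogen on an aromatic nitrogen. The long chain and the two amino groups on the shared core stay as they are.

Among the compounds with values here, no measured pair shows this change on its own. Compound 2 carries the same benzyl on its ring nitrogen and is the weaker of the two, yet its other difference from compound 1 leaves that as no firm guide. The expectation is a step of a 1.5-fold higher number from compound 1 to compound 3 (0.18 log units; within the scatter), small and toward a weaker inhibitor, close to the edge of the scatter. Compound 3 is therefore estimated at 2800 nM, within 900 nM to 9000 nM.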

Compound 3, half-maximal inhibitory concentration: 5300 nM
Beside the measured number, compound 3's estimate is 1.9-fold (0.28 log units) below it, and the stated range covers the measured number.
By their numbers in this assay, from the lowest: compound 1; then compound 3; then compound 2.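

Within the data shown here, this is the first reading of this change on its own. In this assay the benzyl group on the aromatic nitrogen gives a 2.9-fold higher number from compound 1 to compound 3 (0.46 log units; beyond the scatter) and so moves the series toward a weaker inhibitor by a modest amount, with the long chain and the two amino groups left untouched. The ring nitrogen is therefore not indifferent to what it carries, yet replacing its hydrogen with benzyl does not abolish the antiproliferative effect, since compound 3 still gives a measurable half-maximal inhibitory concentration of 5300 nM in this assay. Nothing measured here accounts for why the number rises with benzyl in place.

This single step cannot say whether the loss follows from the size of the group on this nitrogen or from the benzyl ring itself, and a smaller group such as methyl or ethyl would be needed to separate the two. It also leaves open whether a benzyl carrying a carboxylic acid or an amine on its ring would behave like the plain benzyl.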